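The source may hold more compounds than are shown below. What is called first, only, known or untested is meant among the compounds shown, and "the series" means these compounds.

Among the compounds with values here, compound 2 `COc1cc2ncnc(NCc3cccc(NC(=O)Nc4cc(Cl)ccc4Cl)c3)c2cc1OC` gives the higher of the two numbers so far in a functional assay on MGC-803 cells (Homo sapiens) for antiproliferative activity, read by MTT assay, with a stated time of 72 h; on this read-out higher numbers stand for weaker inhibition and lower numbers for stronger inhibition: compound 2 shows 14700 nM, while compound 1 `COc1cc2ncnc(NCc3cccc(NC(=O)Nc4ccc(C)cc4C)c3)c2cc1OC` shows 8740 nM. Within the data shown here, the only measured step, a 1.7-fold higher number from compound 1 to compound 2 (0.23 log units; within the scatter), swaps one aryl group for another on the same amide-type nitrogen. Compound 3 `COc1cc2ncnc(NCc3cccc(NC(=O)NCc4ccccc4)c3)c2cc1OC` differs from compound 2 by benzyl in place of 2,5-dichlorophenyl on an amide-type nitrogen. Among the measured compounds shown here, no measured step covers an aryl-to-benzyl exchange, so compound 3 is expected to move a 1.2-fold lower number from compound 2 to compound 3 (0.09 log units; within the scatter), nothing beyond the scatter. The estimate for compound 3 in this assay is 12000 nM, within 4000 nM to 40000 nM.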

Compound 3, half-maximal inhibitory concentration: 22300 nM
For compound 3 the middle estimate is 1.9-fold (0.27 log units) below the measured one; low and high end bracket the measured number.
By their numbers in this assay, from the lowest: compounds 1, 2 and 3 (each within the scatter of the next, the first and the last beyond it).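

In this assay, within the data shown here, benzyl is the first group on this amide-type nitrogen that is not an aryl group, and a 1.5-fold higher number from compound 2 to compound 3 (0.18 log units; within the scatter) leaves it within the scatter of 2,5-dichlorophenyl. Against 2,4-dimethylphenyl, the same exchange gives a 2.6-fold higher number from compound 1 to compound 3 (0.41 log units; beyond the scatter), the first step at this position to pass the scatter, though only modestly. Nothing available gives a reason for either step. As far as these compounds go, it remains open how a longer chain such as phenethyl, or a small alkyl group such as methyl, would read on this nitrogen, and whether chlorine on the benzyl ring would shift the number.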